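The compounds below may be only part of what the source reports. "The series", "measured", "known", "first", "only" and "open" are said of these compounds alone.

Three compounds share one core. Compound 1 `CCOC(COC(N)=O)C1=C(N2CC2)C(=O)C(C)=C(N2CC2)C1=O` gives 4.62 in a functional assay on L1210 cells (Mus musculus), with a stated time of 1 days; a lower number here means a less potent compound, a higher number a more potent compound, by a factor of ten per unit of this negative logarithm. Compound 2 `COCCC1=C(N2CC2)C(=O)C(C)=C(N2CC2)C1=O` gives 5.12 in this assay, and compound 3 `CC1=C(N2CC2)C(=O)C(C(C)C)=C(N2CC2)C1=O` gives 4.69 in this assay. Going by the values given here, the only step between two compounds that differ in one place is a number 0.43 log units lower from compound 2 to compound 3 (beyond the scatter). Among these three numbers compound 3 stands second highest: it lies within the scatter of compound 1 and beyond the scatter below compound 2.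

Compound 4 `CC1=C(N2CC2)C(=O)C(N2CC2)=C(N2CC2)C1=O` differs from compound 3 by aziridin-1-yl in place of isopropyl on a double-bonded ring carbon. Among the compounds with values here, no measured step exchanges a carbon substituent for an aziridin-1-yl group at that place, so the step of a number 0.43 log units lower from compound 2 to compound 3 (beyond the scatter) bears on it only loosely, showing that the group on a double-bonded ring carbon of this core can shift the read-out by a modest amount. Compound 4 is therefore expected to move away from compound 3 by a modest amount, most plausibly upward, with real uncertainty in both directions. The expected step is a number 0.51 log units higher from compound 3 to compound 4 (beyond the scatter). Compound 4 is estimated at 5.2, within a range from 4.5 to 5.9.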

Compound 4, logarithm of the reciprocal of the active concentration, log(1/C): 5.69
Estimate against measurement, compound 4: 0.49 log units below; the range from low to high includes it.
By their numbers in this assay, from the lowest: compounds 1 and 3 (each within the scatter of the next); then compound 2; then compound 4.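

In this assay, placing aziridin-1-yl on this double-bonded ring carbon gives a number 1.00 log units higher from compound 3 to compound 4 (beyond the scatter) when it replaces isopropyl, and a number 0.57 log units higher from compound 2 to compound 4 (beyond the scatter) when it replaces 2-methoxyethyl. Compound 2 and compound 3 had shown only that two carbon-linked groups at this place give different numbers; compound 4 shows that a group attached through nitrogen, the same aziridin-1-yl found elsewhere on the shared core, stands beyond the scatter above both. Nothing available accounts for why this exchange raises the number.

The compounds shown leave open whether the rise needs the three-membered ring or would also appear with an open-chain amine such as dimethylamino, or with a larger ring such as morpholine. They also leave open how a chlorine atom or a plain hydrogen at this place would compare.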